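A few compounds are considered here, and "the series" means these few. Any claim that something is new, unique, unknown or untested is made for them only; others in the source may bear on it.

Of the compounds shown here, three built on a shared core have been measured in an ADME assay on L02 cells (Homo sapiens) for cytotoxicity, read by MTT assay, with a stated time of 24 h; on this read-out higher numbers stand for weaker inhibition and lower numbers for stronger inhibition. Compound 3 `O=C1/C(=C/c2ccncc2)CN(S(=O)(=O)c2ccc(Cl)cc2)C/C1=C\c1ccccc1C(F)(F)F` gives 14900 nM, compound 2 `Cc1ccc(S(=O)(=O)N2C/C(=C\c3ccncc3)C(=O)/C(=C/c3ccccc3C(F)(F)F)C2)cc1` gives 12800 nM, and compound 1 `CC(=O)Nc1ccc(S(=O)(=O)N2C/C(=C\c3ccncc3)C(=O)/C(=C/c3ccccc3F)C2)cc1` gives 12300 nM. Compound 3 therefore lies within the usual scatter of both others, and the numbers do not separate it from either.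

The next compound, compound 4 `CC(=O)Nc1ccc(S(=O)(=O)N2C/C(=C\c3ccncc3)C(=O)/C(=C/c3ccccc3C(F)(F)F)C2)cc1`, has acetamido in place of chloro on an aromatic carbon, para to a large group, so that a 4-chlorophenyl becomes a 4-acetamidophenyl: acetamido in place of chloro on an aromatic carbon.

Among the measured compounds shown here, only one measured step touches this same place: a 1.2-fold higher number from compound 2 to compound 3 (0.07 log units; within the scatter). It swaps chloro for methyl and stays within the scatter, but it involves no acetamido group, so it is only a weak guide. Compound 1 already carries the 4-acetamidophenyl group and sits at 12300 nM, although it also differs from compound 4 elsewhere, so the two do not form a clean pair.

With both pieces of evidence pointing to little movement in this assay, the expected change is none beyond the scatter, and the estimated step is a 1.1-fold lower number from compound 3 to compound 4 (0.06 log units; within the scatter). Compound 4 is expected at 13000 nM, with an estimated range from 7000 nM to 24000 nM.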

Compound 4, half-maximal inhibitory concentration: 10100 nM
Compound 4: the middle estimate sits 1.3-fold (0.11 log units) above what was measured; the measured number falls inside the stated range.
By their numbers in this assay, from the lowest: compounds 4, 1, 2 and 3 (each within the scatter of the next).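

Among the compounds shown here, compound 4 is the first compound that lets acetamido be read directly against chloro and methyl on an aromatic carbon, para to a large group. In this assay the swap from chloro gives a 1.5-fold lower number from compound 3 to compound 4 (0.17 log units; within the scatter) and the swap from methyl gives a 1.3-fold lower number from compound 2 to compound 4 (0.10 log units; within the scatter) so neither replacement takes the number beyond the scatter, even though acetamido has more heavy atoms and brings a hydrogen-bond donor and a hydrogen-bond acceptor that chloro lacks. For the compounds shown here, compound 4 also provides the first pair that differs at a second place, where trifluoromethyl in place of fluoro on an aromatic carbon gives a 1.2-fold lower number from compound 1 to compound 4 (0.09 log units; within the scatter) and this step also stays within the scatter. Nothing among the measurements shown offers an explanation for how closely these numbers lie.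

The compounds shown leave open whether an amine or a carboxylic acid at the first place would give a step beyond the scatter, since every group there so far gives a step within it. They also leave open whether trifluoromethyl and fluoro would still read alike with chloro or methyl at the first place, as that pair has been read only with acetamido.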